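Phenyl for Methyl: What Compound 3 Might Show

A few compounds are considered here, and "the series" means these few. Any claim that something is new, unique, unknown or untested is made for them only; others in the source may bear on it.

Of the compounds shown here, two have been tested in a functional assay on the whole organism (strain albino) for inhibition, with Rattus norvegicus as the target, read by paw edema, with stated times of 30 min and 2 h, at a dose of 25 mg/kg by the intraperitoneal route; a lower number here means less inhibition, a higher number more inhibition at the dose given (going by the name of the read-out). Compound 1 `COc1ccc(C2=NN(C(=O)NS(=O)(=O)c3ccc(Cl)cc3)CC2c2ccccc2)c(OC)c1` gives 27.3%. Compound 2 `COc1ccc(C2=NN(C(=S)NC(=O)c3ccc(Cl)cc3)CC2C)c(OC)c1` gives 0%. Compound 2 therefore stands at the lower of the two numbers, and the gap to compound 1 lies beyond the usual scatter; since the two compounds differ in more than one place, their values are set side by side only as they stand. Compound 3 `COc1ccc(C2=NN(C(=S)NC(=O)c3ccc(Cl)cc3)CC2c2ccccc2)c(OC)c1` has not yet been measured. It differs from compound 2 in a single place: phenyl in place of methyl on a saturated ring carbon. Among the measured compounds shown here, no step between measured compounds that differ in one place is available, so the size of this change cannot be calibrated. One expects an upward step of moderate size, because compound 1 gives 27.3% while also carrying the phenyl group that compound 2 lacks. Compound 3 is estimated at 15%, with a range from 0% to 35%. The step this estimate means, a number 15 percentage points higher from compound 2 to compound 3 (beyond the scatter), is expected to be upward but not large.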

Compound 3, a percentage reported as inhibition, in the whole organism at one dose (the size of the read-out at that dose, not a potency): 0%
Beside the measured number, compound 3's estimate is 15 percentage points above it; the measured number falls inside the stated range.
By their numbers in this assay, from the lowest: compounds 2 and 3 (each within the scatter of the next); then compound 1.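

In this assay, among the compounds shown here, putting phenyl in place of methyl on this saturated ring carbon gives no change at the digits printed from compound 2 to compound 3 (within the scatter), the first step that can be read at this position. Phenyl on this carbon is therefore not enough by itself to give a reading above zero with this side chain, as compound 3 carries it and gives 0% at the dose used. Since compound 2 and compound 3 both read zero, the step cannot say how much this position matters, and nothing given here bears on why the result came out this way.

The compounds shown leave open whether any other group on this carbon, such as an amine or a short chain ending in a carboxylic acid, would give a reading above zero with this side chain. They also leave open whether the choice between phenyl and methyl matters once a different side chain stands on the ring nitrogen, as no pair shown makes that change in a single place.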